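This account rests on a few compounds, and the source may have more. Where it says the series, first, only, none or still open, it means among the compounds named here.

Compound 3, `CCCCNCc1ccc(Cl)c(-c2ccccc2OC)c1`, stands at the far end of the series in a functional assay on HEK293 cells for agonist activity at 5-hydroxytryptamine receptor 7 (Homo sapiens), read by cAMP accumulation, with a stated time of 30 min; on this read-out lower numbers stand for an effect already at smaller amounts and higher numbers for an effect only at larger amounts of compound. Where compound 1, `COc1ccccc1-c1cc(C2CCNC2)ccc1Cl`, gives 91.2 nM; 92 nM (2 entries) and compound 2, `CNCc1ccc(Cl)c(-c2ccccc2OC)c1`, gives 457 nM; 460 nM (2 entries), compound 3 gives "not active" (no number reported): an entry without a single number, and its further entries in this assay are likewise without one. The two values for compound 1 sit close together (the several entries of compound 1 in this assay, 91.2 nM; 92 nM (2 entries)), as do the two for compound 2 (the several entries of compound 2 in this assay, 457 nM; 460 nM (2 entries)), so the numbers themselves are steady. Going by the values given here, no step between two measured compounds that differ in one place is available, so the position of compound 3 can only be read against the numbers of compound 1 and compound 2, both of which return a measurable response where compound 3 returns none.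

Compound 4, `CCN(CC)Cc1ccc(Cl)c(-c2ccccc2OC)c1`, is built from compound 3 by the rearrangement (diethylamino in place of butylamino on a saturated chain carbon bound to an aromatic carbon), diethylamino in place of butylamino on a saturated chain carbon bound to an aromatic carbon. In this assay compound 4 is expected, on the showing of compound 3 alone, to stay weak, with a fair chance that again only a limit is reported. The estimate for compound 4 is 3000 nM, within a range from 500 nM to 20000 nM.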

Compound 4, half-maximal effective concentration: "not active" (no number reported)
No number was reported for compound 4; the estimate stays without a comparison.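

Going by these compounds alone, compound 3 and compound 4 both come out as "not active" in this assay, with no number reported, so no step between them can be read, and nothing on record bears on this result. The compounds shown leave open whether butylamino and diethylamino on this chain carbon differ at all in this assay.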